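A few compounds are considered here, and "the series" means these few. Any claim that something is new, unique, unknown or untested is made for them only; others in the source may bear on it.

Of the compounds shown here, three have been measured in an assay on Sf9 cells for inhibition of protein deacetylase HDAC6 (Homo sapiens), read by fluorescence, with a stated time of 40 min, tested at 100 nM; a higher number here means more inhibition at the concentration tested (going by the name of the read-out), a lower number less inhibition. Compound 1 `O=C(O)c1ccc(NCc2nc(-c3ccccc3)nn2-c2ccccc2)cc1` gives -0.4%; compound 2 `O=C(NO)c1ccc(NCc2nc(-c3ccc(Cl)cc3)nn2-c2ccccc2)cc1` gives 67.2%; compound 3 `O=C(NO)c1ccc(NCc2nc(-c3ccsc3)nn2-c2ccccc2)cc1` gives 53.4%. Compound 3 thus stands second highest of the three: compound 2 lies above it by a step beyond the scatter, while compound 1 lies far below it.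

Compound 4 `O=C(NO)c1ccc(NCc2nc(-c3ccccc3)nn2-c2ccccc2)cc1` has not yet been measured. Compared with compound 3, the change is phenyl in place of thiophen-3-yl on an aromatic carbon.

Going by the values given here, only one measured step touches the same position. There the change of 4-chlorophenyl to thiophen-3-yl gave a number 13.8 percentage points lower from compound 2 to compound 3 (beyond the scatter), a modest fall. Among the compounds with values here, the step toward compound 4 is different in kind, since phenyl is neither of those two groups, and no measured pair shows phenyl against thiophen-3-yl directly. Compound 1 carries phenyl at this position, but it differs from compound 4 elsewhere, so its value does not speak to this change.

Given that, the step to compound 4 is expected to be small, likely within the scatter, and estimated as a number 4.6 percentage points higher from compound 3 to compound 4 (within the scatter). For compound 4 in this assay the expected value is 58%, with a range from 40% to 75%.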

Compound 4, a percentage reported as inhibition, at one concentration (the size of the read-out at that concentration, not a potency): 72.6%
Compound 4: the middle estimate sits 14.6 percentage points below what was measured; measured number inside the range.
By their numbers in this assay, from the lowest: compound 1; then compound 3; then compounds 2 and 4 (each within the scatter of the next).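

In this assay, going by these compounds alone, the place between two ring nitrogen atoms now has a direct comparison of phenyl and thiophen-3-yl, and the five-membered ring comes out lower (in the step of a number 19.2 percentage points higher from compound 3 to compound 4 (beyond the scatter)), so this swap matters more than the one earlier pair suggested. Removing chloro from the 4-chlorophenyl group makes no readable difference (in the step of a number 5.4 percentage points higher from compound 2 to compound 4 (within the scatter)), so among the three groups tried here, thiophen-3-yl is the one that stands apart, while phenyl and 4-chlorophenyl cannot be told apart. Compound 1 can now also be compared in a single change, and hydroxyamino in place of hydroxy on the carbonyl carbon gives a far larger step than any seen at the ring position (in the step of a number 73 percentage points higher from compound 1 to compound 4 (beyond the scatter)), taking the number from about nothing to the top of the series.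

No measurement shown here explains the gap between phenyl and thiophen-3-yl. Still open, on these data alone, is how other groups at this place would fare, such as a pyridine ring, a methoxy group on the phenyl or a small alkyl chain.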